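The source may report more compounds than this note shows. Statements on the series, on what has been measured and on what is new or still open speak of the compounds shown alone.

Working notes on the series. Three compounds have numbers in an assay on HEK293 cells for binding affinity to 5-hydroxytryptamine receptor 7 (Homo sapiens), read by radioligand binding, tested at 1 uM; on this read-out higher numbers stand for more inhibition at the one concentration tested (going by the name of the read-out) and lower numbers for less inhibition: compound 1 `CC1CN(CCn2ccc3ccc(Br)cc32)CC(C)N1` gives 26%, compound 2 `CN1CCCN(CCn2ccc3cccc(Br)c32)CC1` gives 18%, and compound 3 `CN1CCCN(CCn2ccc3ccc(N)cc32)CC1` gives 0%. Compound 3 stands lowest of the three, beyond the scatter from both compound 2 and compound 1. Within the data shown here, no pair of these differs in one place, so no single step can be read from them.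

Compound 4 `CCc1ccc2ccn(CCN3CCCN(C)CC3)c2c1` has not yet been run in this assay. It differs from compound 3 as follows: ethyl in place of amino on an aromatic carbon. Given that compound 3 gives 0% while the two bromo-bearing compounds reach higher, an upward step of a number 20 percentage points higher from compound 3 to compound 4 (beyond the scatter) is expected, beyond the scatter. Compound 4 is estimated at 20%, within 0% to 40%.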

Compound 4, a percentage reported as inhibition, at one concentration (the size of the read-out at that concentration, not a potency): 66%
Compound 4: middle estimate off by 46 percentage points, on the low side, outside the stated range (above it).
By their numbers in this assay, from the lowest: compound 3; then compounds 2 and 1 (each within the scatter of the next); then compound 4.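

Among these compounds, on this aromatic carbon, in this assay, ethyl in place of amino gives a number 66 percentage points higher from compound 3 to compound 4 (beyond the scatter), so the position is sensitive to the group it carries, which no earlier pair could show. Amino and ethyl differ in size and in hydrogen-bond donors and acceptors, and this single pair cannot separate those differences. Nothing measured here explains the step.

On these data alone, whether methyl or a longer chain such as propyl at this carbon would read like ethyl remains open. So does whether a methoxy group, which has oxygen but no hydrogen-bond donor, would read like ethyl or like amino.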